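Series notes: from compound 1 to compound 3

The source may hold more compounds than are shown below. What is called first, only, known or untested is meant among the compounds shown, and "the series" means these compounds.

Compound 1 `O=C(/C=C/C=C/c1ccccc1)c1cc(Cl)ccc1O` has been measured in an in vitro assay on cells for inhibition of Amine oxidase [flavin-containing] B (Homo sapiens), read by Amplex Red, with a stated time of 15 min (a lower number here means a stronger inhibitor, a higher number a weaker inhibitor), where compound 1 gives 54.8 nM. Among the measured compounds shown here, compound 2 `O=C(/C=C/C=C/c1ccccc1)c1ccccc1O` is the only other measured member; in this assay compound 2 gives 106 nM. For the measured compounds named here, the single step between them, a 1.9-fold higher number from compound 1 to compound 2 (0.29 log units; within the scatter), consists of hydrogen in place of chloro on an aromatic carbon. Going by the values given here, of the two numbers known, compound 1 holds the lower one, but the gap to compound 2 lies within the scatter, so no order between the two can be stated.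

Compound 3 `O=C(/C=C/C=C/c1ccc([N+](=O)[O-])cc1)c1cc(Cl)ccc1O` is not yet measured. Its difference from compound 1 is nitro in place of hydrogen on an aromatic carbon of a six-membered aromatic ring of carbon only, para to a large group. Among the compounds with values here, no measured step bears on this position or this group; the only step at hand, a 1.9-fold higher number from compound 1 to compound 2 (0.29 log units; within the scatter), concerns a different position and stays within the scatter. Nothing in the series therefore points to a shift beyond the scatter in either direction in this assay for compound 3. The number expected for compound 3 is 50 nM, with a range from 15 nM to 180 nM. As a step this expectation amounts to a 1.1-fold lower number from compound 1 to compound 3 (0.04 log units; within the scatter).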

Compound 3, half-maximal inhibitory concentration: 1080 nM
Compound 3: middle estimate off by 22-fold (1.33 log units), on the low side; the whole stated range lies below it.
By their numbers in this assay, from the lowest: compounds 1 and 2 (each within the scatter of the next); then compound 3.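

Among the compounds shown here, the step of a 20-fold higher number from compound 1 to compound 3 (1.29 log units; beyond the scatter) is the first to lie beyond the scatter in this assay, whereas the only earlier step, a 1.9-fold higher number from compound 1 to compound 2 (0.29 log units; within the scatter), stayed within it and concerned a different position. It shows that this position, on the aromatic carbon para to a large group, is not indifferent: on the core of compound 1, nitro in place of hydrogen goes with a much weaker inhibitor, so the ring can no longer be treated as open to substitution without consequence for this assay. This remains a single change at a single position, and no measurement at hand speaks to what lies behind the shift.

Still open, on these data alone, is whether the shift belongs to nitro itself or would follow any group at this place, a question that a fluoro, a methyl, a methoxy or an amine on the same carbon could help to settle. Also open, as far as these compounds go, is whether the same nitro change would give a step of similar size on the core of compound 2, which lacks the chloro group, and how other carbons of this ring respond.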